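Hydroxy exchanged for an aminothiadiazolylsulfanyl arm

The compounds below may be only part of what the source reports. "The series", "measured", "known", "first", "only" and "open" are said of these compounds alone.

Of the compounds shown here, three have been measured in a functional assay on HBL-100 cells (Homo sapiens) for antiproliferative activity, read by sulforhodamine B assay, with a stated time of 48 h; on this read-out higher numbers stand for weaker inhibition of growth and lower numbers for stronger inhibition of growth. Compound 3 `CC1(C)O[C@H]2[C@H](OCc3noc(-c4ccc([N+](=O)[O-])cc4)n3)O[C@H](CO)[C@H]2O1` gives 99000 nM, the highest of the two numbers shown. Compound 1 `Nc1nnc(SC[C@H]2O[C@@H](OCc3noc(-c4ccc(Cl)cc4)n3)[C@@H]3OC4(CCCC4)O[C@@H]32)s1` gives 30000 nM, a lower number and beyond the scatter. Compound 2 `CC1(C)O[C@H]2[C@H](OCc3noc(-c4ccc([N+](=O)[O-])cc4)n3)O[C@H](CSc3ncn[nH]3)[C@H]2O1` reaches only the limit of > 100000 nM in this assay. Among the measured compounds shown here, the single measured step, a number no higher from compound 2 to compound 3 (the limit leaves the size open), runs the opposite way to the change now considered, and because of the limit of > 100000 nM in this assay, at which 1 of the 3 values shown sits, its size cannot be read. Compound 4 `CC1(C)O[C@H]2[C@H](OCc3noc(-c4ccc([N+](=O)[O-])cc4)n3)O[C@H](CSc3nnc(N)s3)[C@H]2O1` differs from compound 3 by (5-amino-1,3,4-thiadiazol-2-yl)sulfanyl in place of hydroxy on a saturated chain carbon bound to a saturated ring carbon. This is the same kind of exchange as the measured step, a heteroaryl sulfanyl arm for hydroxy, though with a different ring; compound 1 carries this very group on another core and gives a lower number than compound 3. For compound 4 the expected step is therefore modest, a 1.7-fold lower number from compound 3 to compound 4 (0.22 log units; within the scatter), with a fair chance that this assay reports only a limit. Compound 4 is estimated at 60000 nM, between 20000 nM and 150000 nM.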

Compound 4, concentration for 50% growth inhibition: > 100000 nM
Compound 4 gave a limit, no number; the forecaster's own chance of this, stated with the estimate: 30%; middle value at least 1.6-fold (0.22 log units) away from the limit.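

In this assay, the (5-amino-1,3,4-thiadiazol-2-yl)sulfanyl arm on a saturated chain carbon bound to a saturated ring carbon brings no gain over hydroxy: the result is a number no lower from compound 3 to compound 4 (the limit leaves the size open). Compound 4 gives > 100000 nM, which is a limit and not a number. Both sulfur-linked heteroaryl arms shown at this place on the shared core now end at that limit, so the 1H-1,2,4-triazol-5-yl and 5-amino-1,3,4-thiadiazol-2-yl rings cannot be told apart, and no step to compound 4 has a readable size: the limit of > 100000 nM in this assay, at which 2 of the 4 values shown sit.

From the compounds shown here alone, how far compound 2 and compound 4 lie past the limit stays open. Going by these compounds, it is also open whether an amine or a carboxylic acid in place of hydroxy at this carbon would give a readable number in this assay.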